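Methoxy Added to a Thiazole Aminopyridine Solubility Series

A few compounds are considered here, and "the series" means these few. Any claim that something is new, unique, unknown or untested is made for them only; others in the source may bear on it.

The series rests on a shared core, seen in compound 1 `COc1ccc(Nc2nc(-c3ccccn3)cs2)cc1` and compound 2 `COc1ccc(Nc2nc(-c3ccccn3)cs2)cc1OC`. In a physicochemical assay for solubility, in phosphate buffer, with a stated time of 2 h, at pH 7.4 (a lower number here means a less soluble compound, a higher number a more soluble compound), compound 1 gives 80000 nM, while compound 2 gives 10000 nM. The change between them is methoxy in place of hydrogen on an aromatic carbon, and it produced an 8.0-fold lower number from compound 1 to compound 2 (0.90 log units; beyond the scatter).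

Compound 3 `Clc1ccc(Nc2nc(-c3ccccn3)c(Cl)s2)nc1` carries a different core; how its core differs from that of compound 1 is not broken down here. In this assay compound 3 reaches only a limit, < 10000 nM, which is the limit of < 10000 nM in this assay, at which 1 of the 3 values shown sits.

Compound 4 `COc1ccnc(-c2nc(Nc3ccc(Cl)cn3)sc2Cl)c1` is not yet measured. It differs from compound 3 by methoxy in place of hydrogen on an aromatic carbon. This is the same kind of change as that from compound 1 to compound 2, though the place differs: in compound 2 the methoxy sits on a six-membered aromatic ring of carbon only, ortho to a methoxy group, whereas in compound 4 it sits on a six-membered aromatic ring with 1 nitrogen, opposite the ring nitrogen.

Because compound 2 gave an 8.0-fold lower number from compound 1 to compound 2 (0.90 log units; beyond the scatter), a similar downward step, a step that the limit leaves unreadable from compound 3 to compound 4, is expected for compound 4. Since compound 3 already sits at a limit, compound 4 is estimated at 2500 nM, within 400 nM to 10000 nM, most likely reported only as a limit.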

Compound 4, solubility: < 10000 nM
Compound 4: a limit, no number (the forecaster's own chance of this, stated with the estimate: 75%); the middle value does not contradict the limit.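

In this assay compound 4 gives only a limit, < 10000 nM. No step can be read from compound 3 to compound 4, as both compounds stand at the same limit: the limit of < 10000 nM in this assay, at which 2 of the 4 values shown sit.

The compounds shown leave open where the true values of compound 3 and compound 4 lie, and whether methoxy in place of hydrogen changes the solubility on this core.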